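The compounds below may be only part of what the source reports. "The series", "measured", "known", "first", "only" and "open" are said of these compounds alone.

Working notes on the series in an ADME assay on microsomes from liver (Homo sapiens) for metabolic stability, read by LC-MS, with a stated time of 30 min, tested at 0.1 uM; on this read-out higher numbers stand for a more stable compound and lower numbers for a less stable compound. Compound 1 `FC(F)(F)c1cccc(-c2nc3cnc(Nc4ccccn4)cc3[nH]2)c1` gives 69%, compound 2 `FC(F)(F)c1cccc(-c2nc3cnc(Nc4cccnn4)cc3[nH]2)c1` gives 84% and compound 3 `FC(F)(F)c1ccc(Nc2cc3[nH]c(-c4cccc(C(F)(F)F)c4)nc3cn2)nc1` gives 90%. Compound 3 stands clear of compound 1, as a number 21 percentage points higher from compound 1 to compound 3 (beyond the scatter) shows, whereas a number 6 percentage points higher from compound 2 to compound 3 (within the scatter) does not separate it from compound 2.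

The next structure is compound 4 `CC1(c2nc3cnc(Nc4ccc(C(F)(F)F)cn4)cc3[nH]2)CC1`. Its change is 1-methylcyclopropyl in place of 3-(trifluoromethyl)phenyl on an aromatic carbon. Compound 4 retains the 5-(trifluoromethyl)pyridin-2-yl group on the nitrogen.

Going by the values given here, no measured step tests a change on this aromatic carbon. All three steps concern the group on the nitrogen, so they offer a scale only: a number 15 percentage points higher from compound 1 to compound 2 (beyond the scatter) and a number 21 percentage points higher from compound 1 to compound 3 (beyond the scatter) are both modest. Replacing 3-(trifluoromethyl)phenyl with 1-methylcyclopropyl is therefore an untested change, and the uncertainty is wide.

No step beyond the scatter is expected in this assay, with a lean towards a lower number, since compound 3 at 90% leaves little room upward. The estimated step is a number 8 percentage points lower from compound 3 to compound 4 (within the scatter). For compound 4 the expected value is 82%, with an estimated range of 62% to 94%.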

Compound 4, percent of the compound remaining: 66%
Estimate against measurement, compound 4: 16 percentage points above; low and high end bracket the measured number.
By their numbers in this assay, from the lowest: compounds 4 and 1 (each within the scatter of the next); then compounds 2 and 3 (each within the scatter of the next).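

In this assay, the group on the aromatic carbon between two ring nitrogen atoms proves able to move the read-out: with the 5-(trifluoromethyl)pyridin-2-yl group on the nitrogen held constant, 1-methylcyclopropyl in place of 3-(trifluoromethyl)phenyl gives a number 24 percentage points lower from compound 3 to compound 4 (beyond the scatter) and is the only step shown at this position. Stability in this series therefore does not rest on the group on the nitrogen alone, as compound 3 carries the same 5-(trifluoromethyl)pyridin-2-yl group as compound 4, and in this assay compound 4 still reads 66%. No measurement at hand accounts for this step.

With a single replacement shown at this position, it stays open whether the step follows from losing the six-membered aromatic ring, from losing the trifluoromethyl group on that ring or from the 1-methylcyclopropyl group itself. A plain phenyl, a tert-butyl group or a morpholine on this aromatic carbon would separate these readings, and pyridazin-3-yl on the nitrogen would test whether the step carries over to another group there.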